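Carbamate Oxygen Swap: tert-Butyl Gives Way to Pyridinylmethyl

This account rests on a few compounds, and the source may have more. Where it says the series, first, only, none or still open, it means among the compounds named here.

Compound 3 `Cc1cc(NC(=O)OC(C)(C)C)nn1Cc1cc(Cl)ccc1OCc1ccccc1` carries a (tert-butoxycarbonyl)amino group on the shared core. In an in vivo ADME assay on the whole organism (blood) for pharmacokinetics, with Rattus norvegicus as the target (a higher number here means faster removal of the compound, a lower number slower removal), compound 3 gives 42 mL/min/kg and stands lowest of the two numbers in hand. Its nearest neighbour compound 2 `Cc1cc(C(=O)NCc2ccccn2)nn1Cc1cc(Cl)ccc1OCc1ccccc1` gives 68 mL/min/kg in this assay, and the change a 1.6-fold lower number from compound 2 to compound 3 (0.21 log units; within the scatter) stays within the scatter. For compound 1 `Cc1cc(C(=O)Nc2ccccc2)nn1Cc1cc(Cl)ccc1OCc1ccccc1` the entry in this assay reads "not determined" (no result reported), so it has no number in this assay at all. Compound 4 `Cc1cc(NC(=O)OCc2ccccn2)nn1Cc1cc(Cl)ccc1OCc1ccccc1` differs from compound 3 in a single place: (pyridin-2-yl)methyl in place of tert-butyl on an oxygen next to a carbonyl group is the change. For the measured compounds named here, only the step from compound 2 to compound 3 bears on it, since compound 2 is the one measured compound that carries a (pyridin-2-yl)methyl group, there on a nitrogen rather than on an oxygen, and that step was within the scatter. One therefore expects for compound 4 a change of a 1.2-fold higher number from compound 3 to compound 4 (0.08 log units; within the scatter) in this assay, none beyond the scatter in either direction. The estimate for compound 4 in this assay is 50 mL/min/kg with a range from 25 mL/min/kg up to 100 mL/min/kg around it.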

Compound 4, clearance: 98 mL/min/kg
Estimate against measurement, compound 4: 2.0-fold (0.29 log units) below; measured number inside the range.
By their numbers in this assay, from the lowest: compounds 3, 2 and 4 (each within the scatter of the next, the first and the last beyond it).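

For the compounds shown here, on the oxygen next to the carbonyl group, the exchange of tert-butyl for (pyridin-2-yl)methyl gives the first step in this assay that clears the scatter: a 2.3-fold higher number from compound 3 to compound 4 (0.37 log units; beyond the scatter) is a modest change, but it shows that the number responds to the group at this place. By contrast, a 1.4-fold higher number from compound 2 to compound 4 (0.16 log units; within the scatter) stays within the scatter, so (((pyridin-2-yl)methoxy)carbonyl)amino and ((pyridin-2-yl)methyl)carbamoyl on the aromatic carbon cannot be told apart here. No evidence accompanies these compounds to explain the step.

The compounds shown leave open whether the step depends on the ring nitrogen, which a benzyl group on the same oxygen would test. They also leave open how a small methyl or a longer alkyl chain at that place would compare with tert-butyl and (pyridin-2-yl)methyl.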